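Methyl on the chain: a second look

The compounds below may be only part of what the source reports. "The series", "measured", "known", "first", "only" and "open" are said of these compounds alone.

Measured compounds:
compound 1, `CCCCCC(=O)NCC(C)(C)CC1=C(O)C(=O)c2ccccc2C1=O`, 40200 nM
compound 2, `CCCCCCC(=O)NCC(C)(C)CC1=C(O)C(=O)c2ccccc2C1=O`, 28200 nM
compound 3, `CCCCCCCC(=O)OCC(C)(C)CC1=C(O)C(=O)c2ccccc2C1=O`, 38300 nM

All three were tested in a functional assay on KB cells (Homo sapiens) for cytotoxicity, read by resazurin assay, with a stated time of 3 days; a lower number here means a stronger inhibitor, a higher number a weaker inhibitor. Compound 2 differs from compound 1 by methyl in place of hydrogen on a saturated chain carbon, five bonds along the chain from a carbonyl carbon, and this gave a 1.4-fold lower number from compound 1 to compound 2 (0.15 log units; within the scatter). Compound 3 stands close to compound 1; the difference between their two cores is not broken down here. Compound 4, `CCCCCCC(C)C(=O)OCC(C)(C)CC1=C(O)C(=O)c2ccccc2C1=O`, is not yet measured and differs from compound 3 by methyl in place of hydrogen on a saturated chain carbon bound to a carbonyl carbon and a saturated chain carbon. This is the same kind of change as from compound 1 to compound 2, but not the same: there the methyl sits on a saturated chain carbon five bonds along the chain from a carbonyl carbon, here on a saturated chain carbon bound to a carbonyl carbon and a saturated chain carbon. In this assay, going by the values given here, the step is expected to be a 1.3-fold lower number from compound 3 to compound 4 (0.11 log units; within the scatter) because the earlier step of a 1.4-fold lower number from compound 1 to compound 2 (0.15 log units; within the scatter) stayed within the scatter; the new place of the methyl has no measured counterpart. Compound 4 is therefore estimated at 30000 nM, between 14000 nM and 65000 nM.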

Compound 4, half-maximal inhibitory concentration: 16800 nM
Compound 4: middle estimate off by 1.8-fold (0.25 log units), on the high side, within the range that was stated.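

In this assay the methyl on the chain carbon bound to the carbonyl carbon gave a 2.3-fold lower number from compound 3 to compound 4 (0.36 log units; beyond the scatter). Going by these compounds alone, only this step lies beyond the scatter, yet the gap between it and the earlier step does not, so the two cores cannot be told apart on this change: the same change on two cores in this assay, a 1.4-fold lower number (0.15 log units; within the scatter) from compound 1 to compound 2 and a 2.3-fold lower number (0.36 log units; beyond the scatter) from compound 3 to compound 4, 1.6-fold (0.20 log units) apart, within the scatter of two such steps. Within the data shown here, this does not show that the change carries over with a fixed size: the methyl sits in a different place in each pair, and only two pairs are at hand.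

The compounds shown leave open what an ethyl or a hydroxyl would do in place of this methyl. They also leave open whether a methyl in this same place would give a like step on the core of compound 1.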